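Three Sulfonyl Aryl Variants, All at the Assay Limit

This account rests on a few compounds, and the source may have more. Where it says the series, first, only, none or still open, it means among the compounds named here.

Compound 1 `O=S(=O)(Nc1ccc2oc(-c3ccccc3)nc2c1)c1ccccc1Cl` gives only a limit in an assay on isolated protein for inhibition of malate dehydrogenase, mitochondrial (Sus scrofa), with stated times of 45 min and 30 min (on this read-out higher numbers stand for weaker inhibition and lower numbers for stronger inhibition), namely > 63000 nM.
Compound 2 `O=S(=O)(Nc1ccc2oc(-c3ccccc3)nc2c1)c1cccs1` gives only a limit in this assay, namely > 63000 nM.
Compound 3 `C=Cc1ccc(S(=O)(=O)Nc2ccc3oc(-c4ccccc4)nc3c2)cc1` gives only a limit in this assay, namely > 63000 nM.

Compound 3 therefore stands at the same place as the other two shown values: no number is known for it, only a limit, and this is true of every value shown, as the limit of > 63000 nM in this assay, at which 3 of the 3 values shown sit, states. The steps between the measured compounds carry no readable size for this reason: a step that the two limits leave unreadable from compound 1 to compound 2, a step that the two limits leave unreadable from compound 1 to compound 3 and a step that the two limits leave unreadable from compound 2 to compound 3.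

The next compound, compound 4 `O=S(=O)(Nc1ccc2oc(-c3ccccc3)nc2c1)c1cccc(O)c1`, differs from compound 3 in one place: 3-hydroxyphenyl in place of 4-vinylphenyl on a sulfonyl sulfur. Going by the values given here, none of the measured steps gives a usable size for this kind of change, since all of them run between two limits. Among the compounds with values here, the only guidance is that three different groups on the sulfonyl sulfur all left the value at the limit. Compound 4 is therefore expected to land at or near that limit as well, an estimated 80000 nM with a range from 20000 nM to 300000 nM. The step this estimate implies, a step that the limit leaves unreadable from compound 3 to compound 4, is expected to be none beyond the scatter.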

Compound 4, half-maximal inhibitory concentration: > 63000 nM
Compound 4 was reported as a limit (the forecaster's own chance of this, stated with the estimate: 85%); the middle value does not contradict the limit.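

Compound 4, like compound 1, compound 2 and compound 3, is reported only as a limit, so none of the steps between them can be read: the limit of > 63000 nM in this assay, at which 4 of the 4 values shown sit.

The compounds shown leave open how far these four actually differ, and whether any group on the sulfonyl sulfur would give a true number in this assay.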